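The source may hold more compounds than are shown below. What is called first, only, known or untested is meant among the compounds shown, and "the series" means these compounds.

Measured in a functional assay on MKN-45 cells (Homo sapiens) for cytotoxicity; on this read-out higher numbers stand for weaker inhibition and lower numbers for stronger inhibition:
- Compound 1 `COc1ccc(S(=O)(=O)N2CCc3cccc(NC(=O)c4cccs4)c32)cc1`: 31 nM
- Compound 2 `COc1ccc(S(=O)(=O)N2CCc3cccc(NC(=O)Oc4ccccc4)c32)cc1`: > 10000 nM (a limit of the assay, not a number)
- Compound 3 `COc1ccc(S(=O)(=O)N2CCc3cccc(NC(C)=O)c32)cc1`: 61 nM

Compound 3, at 61 nM, lies within the scatter of compound 1, at 31 nM: a 2.0-fold higher number from compound 1 to compound 3 (0.29 log units; within the scatter). Compound 2 has only a limit in this assay, and an at least 160-fold lower number from compound 2 to compound 3 (2.21 log units; beyond the scatter).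

Compound 4 `COc1ccc(S(=O)(=O)N2CCc3cccc(NCc4ccccc4)c32)cc1` keeps the shared core of compound 3 but carries benzyl in place of acetyl on a nitrogen on an aromatic ring, so that acetamido becomes benzylamino. Among the compounds with values here, the carbonyl is therefore lost, and no measured step removes it. All three measured steps only exchange the group on that carbonyl, so they bear on this change indirectly. They also pull in different directions: the exchange can be silent, as in a 2.0-fold higher number from compound 1 to compound 3 (0.29 log units; within the scatter), or very large, as in an at least 320-fold higher number from compound 1 to compound 2 (2.50 log units; beyond the scatter). Compound 2 shows through an at least 160-fold lower number from compound 2 to compound 3 (2.21 log units; beyond the scatter) that a larger group can cost a great deal, whereas compound 1 shows that one need not.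

A moderate rise in the number is therefore expected, with wide uncertainty: an 8.2-fold higher number from compound 3 to compound 4 (0.91 log units; beyond the scatter). For compound 4 the estimated value is 500 nM, with an expected range of 40 nM to 8000 nM.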

Compound 4, half-maximal inhibitory concentration: > 10000 nM
Compound 4: only a limit was reported; the forecaster's own chance of this, stated with the estimate: 20%; at least 20-fold (1.30 log units) between middle value and limit.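

In this assay compound 4 gives > 10000 nM, a limit of the assay and not a number. This is the first change shown that removes the carbonyl rather than exchanging the group on it, and it is large against both compounds that have a measured value: an at least 160-fold higher number from compound 3 to compound 4 (2.21 log units; beyond the scatter), and an at least 320-fold higher number from compound 1 to compound 4 (2.50 log units; beyond the scatter). Compound 2 keeps its carbonyl and compound 4 loses it, yet the step between them cannot be read, as both sit at the same limit: the limit of > 10000 nM in this assay, at which 2 of the 4 values shown sit.

Acetyl gives way to benzyl in a single change, so the compounds shown do not separate the loss of the carbonyl from the arrival of the aromatic ring. Going by these compounds, a benzoyl group would keep the carbonyl and bring an aromatic ring, a methylamino group would lose the carbonyl and bring no ring, and how either would read in this assay stays open.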